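Benzimidazole in place of fluoropyridine on a weak scaffold

The compounds below may be only part of what the source reports. "The series", "measured", "known", "first", "only" and "open" are said of these compounds alone.

Compound 3 `CCN(c1ccc(C#N)c(Cl)c1)c1cc(-c2ccc(F)nc2)ccc1C` was tested in a functional assay on PC-3 cells (Homo sapiens) for antiproliferative activity, read by CCK-8 assay, with a stated time of 6 days; on this read-out higher numbers stand for weaker inhibition and lower numbers for stronger inhibition. In this assay compound 3 gives > 30000 nM, which is a limit of the assay and not a measured number. Compound 1 `CCN(c1ccc(C#N)c(Cl)c1)c1cc(-n2ccnc2)ccc1C` likewise gives only a limit, > 30000 nM, in this assay. Compound 2 `CCN(c1ccc(C#N)c(Cl)c1)c1cc(-c2cn[nH]c2)ccc1C` gives 15300 nM in this assay. Across these three, an at least 1.9-fold lower number from compound 1 to compound 2 (0.29 log units; that floor lies within the scatter) and an at least 1.9-fold higher number from compound 2 to compound 3 (0.29 log units; that floor lies within the scatter) are small, and a step that the two limits leave unreadable from compound 1 to compound 3, because of the limit of > 30000 nM in this assay, at which 2 of the 3 values shown sit. Compound 4 `CCN(c1ccc(C#N)c(Cl)c1)c1cc(-n2cnc3ccccc32)ccc1C` differs from compound 3 by 1H-benzimidazol-1-yl in place of 6-fluoropyridin-3-yl on an aromatic carbon. With compound 1 and compound 3 both at the limit, compound 4 is expected to show a number no higher from compound 3 to compound 4 (the limit leaves the size open), staying weak. The estimated value of compound 4 is 30000 nM, expected between 8000 nM and 100000 nM.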

Compound 4, half-maximal inhibitory concentration: 8160 nM
The estimate for compound 4 lay 3.7-fold (0.57 log units) above the measured number; low and high end bracket the measured number.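

In this assay, this position, para to a methyl group, now shows its first steps beyond the scatter: 1H-benzimidazol-1-yl gives an at least 3.6-fold lower number from compound 3 to compound 4 (0.56 log units; beyond the scatter) and an at least 3.6-fold lower number from compound 1 to compound 4 (0.56 log units; beyond the scatter). Against 1H-pyrazol-4-yl the picture differs, with a 1.9-fold lower number from compound 2 to compound 4 (0.27 log units; within the scatter), so these two groups cannot be ranked. The position therefore accepts a group with a second aromatic ring and still gives a readable number.

Whether that added carbon-only ring accounts for the step stays open. So does how an amine or a carboxylic acid would behave at this position.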